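The compounds below may be only part of what the source reports. "The series", "measured", "known", "first", "only" and "open" are said of these compounds alone.

Compound 1 `N#Cc1c(Cl)nc(SCc2nc3ccccc3[nH]2)nc1-c1ccccc1`: 4.46 nM
Compound 2 `N#Cc1c(NN)nc(SCc2nc3ccccc3[nH]2)nc1-c1ccccc1`: 3.9 nM

In a functional assay on U-937 cells (Homo sapiens) for cytotoxicity, read by MTT assay, with a stated time of 3 days (a lower number here means a stronger inhibitor, a higher number a weaker inhibitor), compound 2 gives 3.9 nM and stands level with compound 1 at 4.46 nM, the two numbers lying within the scatter of each other. Compound 3 `N#Cc1c(Nc2ccccc2)nc(SCc2nc3ccccc3[nH]2)nc1-c1ccccc1` carries phenyl in place of amino on a nitrogen on an aromatic ring. Among the measured compounds shown here, the one measured step that bears on this is a 1.1-fold lower number from compound 1 to compound 2 (0.06 log units; within the scatter). It is a different exchange and thin evidence, so no step beyond the scatter is expected in this assay, though with a wide margin. The estimated step is a 1.3-fold higher number from compound 2 to compound 3 (0.11 log units; within the scatter). For compound 3 the expected value is 5 nM, with an estimated range from 1.5 nM to 18 nM.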

Compound 3, half-maximal inhibitory concentration: 3.28 nM
Compound 3: middle estimate off by 1.5-fold (0.18 log units), on the high side; low and high end bracket the measured number.
By their numbers in this assay, from the lowest: compounds 3, 2 and 1 (each within the scatter of the next).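

In this assay, phenyl in place of amino on the nitrogen leaves the number level (a 1.2-fold lower number from compound 2 to compound 3 (0.08 log units; within the scatter)), and anilino in place of chloro on the aromatic carbon does the same (a 1.4-fold lower number from compound 1 to compound 3 (0.13 log units; within the scatter)). This place on the shared core thus holds chloro, aminoamino and anilino, the last with its six-membered aromatic ring, without any step beyond the scatter. No available evidence explains this level behaviour.

As far as these compounds go, whether a carboxylic acid or a morpholine at this place would shift the number remains open, as does the effect of a chloro or methoxy group on the phenyl ring of the anilino.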